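The compounds below may be only part of what the source reports. "The series", "measured", "known", "first", "only" and "open" are said of these compounds alone.

Working notes on the amide series. Compound 1 `O=C(c1ccc(F)cc1)N1CCc2nc(COc3ccccc3F)oc2C1` and compound 2 `O=C(c1cc2ccccc2[nH]1)N1CCc2nc(COc3ccccc3)oc2C1` share the core and differ at the amide and at the aryl ether. In a functional assay on HEK293 cells for positive allosteric modulation of metabotropic glutamate receptor 5 (Homo sapiens), read by calcium flux (a higher number here means a larger maximal response, a lower number a smaller maximal response), compound 1 gives 78%. In this assay compound 2 gives 40%, the lower of the two numbers; its gap to compound 1 lies beyond the usual scatter. Because the two compounds differ in more than one place, nothing here is attributed to either change on its own.

Compound 3 `Cn1c(C(=O)N2CCc3nc(COc4ccccc4)oc3C2)cc2ccccc21` follows from compound 2 by one change: methyl in place of hydrogen on an aromatic nitrogen. Going by the values given here, no measured pair in this set isolates such a change, so the direction is open and only a modest shift, if any, is assumed. The step of a number 5 percentage points higher from compound 2 to compound 3 (within the scatter) is expected to be small and not clearly beyond the scatter, either way. Among the compounds with values here, for compound 3 in this assay the estimate is 45%, with a range from 25% to 70%, the width reflecting that the set gives no precedent for this change.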

Compound 3, largest response reached (reported as percent of maximum), in percent of the reference or control that the assay uses: 57%
Estimate against measurement, compound 3: 12 percentage points below; low and high end bracket the measured number.
By their numbers in this assay, from the lowest: compound 2; then compound 3; then compound 1.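

In this assay, going by these compounds alone, methyl in place of hydrogen on an aromatic nitrogen gives a number 17 percentage points higher from compound 2 to compound 3 (beyond the scatter) and provides the first comparison that differs in one place, so this change can be read on its own. The step shows that the hydrogen on this nitrogen of the five-membered aromatic ring is not needed for the maximal response: with a methyl there, next to the ring atom that bears a large group, the response is retained and rises beyond the scatter. No available measurement bears on why the response moves in this direction.

The single methyl leaves open whether the response keeps rising, levels off or falls with a larger group on this nitrogen, such as an ethyl, a longer chain or a chain ending in an amine. From the compounds shown here alone, it also remains open whether the same change gives a step of similar size when the aryl ether of compound 1 replaces that of compound 3, since this pair carries only one aryl ether.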